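This account rests on a few compounds, and the source may have more. Where it says the series, first, only, none or still open, it means among the compounds named here.

Three ureas sharing one core have been measured. In an ADME assay on A549 cells (Homo sapiens) for cytotoxicity, read by MTT assay, tested at 10 uM (on this read-out higher numbers stand for a weaker effect at the one concentration tested and lower numbers for a stronger effect), compound 1 `C#CCSc1nsc(NC(=O)Nc2ccccc2Cl)n1` gives 89.9%, compound 2 `C=CCSc1nsc(NC(=O)Nc2ccc(Cl)cc2C(F)(F)F)n1` gives 95.8%, and compound 3 `O=C(Nc1nc(SCCOc2ccccc2)ns1)Nc1ccc(F)cc1F` gives 95.5%. Compound 3 stands second highest of the three numbers, nearest to compound 2, whose number is a little higher but within the scatter, and furthest from compound 1, whose number is lower yet still within the scatter. Compound 4 `C=CCSc1nsc(NC(=O)Nc2ccc(F)cc2F)n1` differs from compound 3 in one place: vinyl in place of phenoxymethyl on a saturated chain carbon bound to a sulfur. For the measured compounds named here, no pair of measured compounds isolates this change. With compound 1 giving 89.9% and compound 2 giving 95.8%, both close to compound 3, the step is expected to be none beyond the scatter, a number 2.5 percentage points lower from compound 3 to compound 4 (within the scatter). Compound 4 is therefore estimated at 93%, with a range from 85% to 100%.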

Compound 4, a percentage reported as activity, at one concentration (the size of the read-out at that concentration, not a potency): 90.2%
Estimate against measurement, compound 4: 2.8 percentage points above; measured number inside the range.
By their numbers in this assay, from the lowest: compounds 1, 4, 3 and 2 (each within the scatter of the next).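

For the compounds shown here, compound 3 and compound 4 form the first pair that isolates this position, and vinyl in place of phenoxymethyl on a saturated chain carbon bound to a sulfur gives a number 5.3 percentage points lower from compound 3 to compound 4 (within the scatter) in this assay. At this position, then, the read-out tolerates the loss of the aromatic ring and the oxygen, as 2-phenoxyethyl gives way to allyl, with the step staying within the scatter. No measured evidence bears on this result. From the compounds shown here alone, whether an amine, a carboxylic acid or a longer chain at this position would also stay within the scatter remains open, as does whether this step would hold with a different aryl group on the urea.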